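The source may report more compounds than this note shows. Statements on the series, on what has been measured and on what is new or still open speak of the compounds shown alone.

Measured so far:
compound 1, `N#C/C(C(=O)Nc1ccccc1)=c1/s/c(=C\c2ccccc2)c(=O)n1-c1ccccc1`: 11000 nM
compound 2, `N#C/C(C(=O)Nc1ccccc1)=c1/s/c(=C\c2ccccc2O)c(=O)n1-c1ccccc1`: 83100 nM

These two numbers come from a functional assay on HepG2 cells (Homo sapiens) for cytotoxicity, read by sulforhodamine B assay, with a stated time of 48 h; on this read-out higher numbers stand for weaker inhibition and lower numbers for stronger inhibition. For the measured compounds named here, compound 1 stands lowest of the two, with compound 2 the nearest at a higher number; the one step in hand, a 7.6-fold higher number from compound 1 to compound 2 (0.88 log units; beyond the scatter), is a hydroxy in place of hydrogen on an aromatic carbon, sitting on a different part of the shared core from the change considered here. Compound 3, `N#C/C(C(=O)Nc1ccc(Cl)cc1)=c1/s/c(=C\c2ccccc2)c(=O)n1-c1ccccc1`, has not yet been measured. It differs from compound 1 by chloro in place of hydrogen on an aromatic carbon. Going by the values given here, no measured step touches the phenylcarbamoyl group; the only known step, from compound 1 to compound 2, concerns another group, so it bears only loosely on this change. Compound 3 is therefore expected to stay close to compound 1, with an expected step of no change at the digits printed from compound 1 to compound 3 (within the scatter), nothing beyond the scatter in either direction. The estimate for compound 3 in this assay is 11000 nM, with a range from 4000 nM to 30000 nM.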

Compound 3, half-maximal inhibitory concentration: 49100 nM
Compound 3: middle estimate off by 4.5-fold (0.65 log units), on the low side, and the stated range ends below it.
By their numbers in this assay, from the lowest: compound 1; then compounds 3 and 2 (each within the scatter of the next).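

In this assay, the phenylcarbamoyl group proves sensitive to a small change: going to (4-chlorophenyl)carbamoyl gives a 4.5-fold higher number from compound 1 to compound 3 (0.65 log units; beyond the scatter) and so weakens inhibition beyond the scatter. Together with a 7.6-fold higher number from compound 1 to compound 2 (0.88 log units; beyond the scatter) on another part of the shared core, this means that both single changes shown move towards weaker inhibition, and neither improves on compound 1. Nothing at hand bears on the cause of the chloro step.

The compounds shown leave open whether this loss belongs to chloro itself or to any group at this place on the ring, since they do not show how a fluoro, a methoxy, an amine or a carboxylic acid would behave there. They also leave open whether a chloro elsewhere on the same ring would give a similar step.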